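Aryl swap at the shared core: compound 3 to compound 4

A few compounds are considered here, and "the series" means these few. Any claim that something is new, unique, unknown or untested is made for them only; others in the source may bear on it.

Compound 1 `COc1ccc(-c2cn3ccnc3c(-c3ccc4ncn(C5CCCCC5)c4c3)n2)cc1` gives 97.4% in a functional assay on MDA-MB-468 cells (Homo sapiens) for inhibition, read by sulforhodamine B assay, with a stated time of 48 h, tested at 10 uM; a lower number here means less inhibition, a higher number more inhibition at the concentration tested (going by the name of the read-out). Within the data shown here, compound 2 `c1cn2cc(-c3ccsc3)nc(-c3ccc4ncn(C5CCCCC5)c4c3)c2n1` gives 21.8% in this assay; the one measured step is a number 75.6 percentage points lower from compound 1 to compound 2 (beyond the scatter). Compound 3 `CCc1ccc(-c2cn3ccnc3c(-c3ccc4ncn(Cc5ccccc5)c4c3)n2)cc1` gives 17.2%, the lowest of the three numbers: compound 2 stands near it, within the scatter, and compound 1 stands far above it, beyond the scatter. Compound 4 `Cc1cccc(-c2cn3ccnc3c(-c3ccc4ncn(Cc5ccccc5)c4c3)n2)c1` is not yet measured; its change from compound 3 is 3-methylphenyl in place of 4-ethylphenyl on an aromatic carbon. Among the measured compounds shown here, only the step from compound 1 to compound 2 concerns the same aromatic carbon, and that step exchanged a phenyl group for thiophen-3-yl, so it is a weak guide. For the measured compounds named here, no step between two substituted phenyl groups at this carbon is known. The step of a number 2.8 percentage points higher from compound 3 to compound 4 (within the scatter) is expected to stay within the scatter. Compound 4 is estimated at 20%, between 5% and 45%.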

Compound 4, a percentage reported as inhibition, at one concentration (the size of the read-out at that concentration, not a potency) in the MDA-MB-468 assay: 16.6%
For compound 4 the middle estimate is 3.4 percentage points above the measured one, within the range that was stated.
By their numbers in the MDA-MB-468 assay, from the lowest: compounds 4, 3 and 2 (each within the scatter of the next); then compound 1.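

Among these compounds, in the MDA-MB-468 assay compound 3 gives 17.2% and compound 4 gives 16.6%; the first exchange between two substituted phenyl groups at this aromatic carbon gives a step of a number 0.6 percentage points lower from compound 3 to compound 4 (within the scatter) and so does not separate 4-ethylphenyl from 3-methylphenyl. In a physicochemical assay for lipophilicity, using the shake flask method, in phosphate buffer, measured as octanol-water partition, with a stated time of 85 min, at pH 7.4 (on this read-out lower numbers stand for lower lipophilicity and higher numbers for higher lipophilicity), compound 3 gives 1.96 and compound 4 gives 2.16; the same change gives a step of a number 0.20 log units higher from compound 3 to compound 4 (within the scatter) and does not separate them either. No measurement at hand offers a reason for either result.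

Going by these compounds, it remains open whether 4-methoxyphenyl would raise the number alongside the other substituent shared by compound 3 and compound 4. A phenyl group carrying an amine or a carboxylic acid at this carbon also remains untested in the compounds shown.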